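The source may hold more compounds than are shown below. What is called first, only, known or untested is meant among the compounds shown, and "the series" means these compounds.

Measured so far in an assay on CHO cells for displacement of a labelled ligand from Substance-P receptor (Homo sapiens), in the presence of a further agent that is not named here; a lower number here means a stronger inhibitor, a higher number a weaker inhibitor:
compound 1 `C[C@@H](O[C@H]1CN2C(=O)C=C(c3cc[n+]([O-])cc3)CC2[C@@H]1c1ccc(F)cc1)c1cc(C(F)(F)F)cc(C(F)(F)F)c1` gives 2.1 nM;
compound 2 `C[C@@H](O[C@H]1CN2C(=O)C=C(C3=CCC(O)CC3)CC2[C@@H]1c1ccc(F)cc1)c1cc(C(F)(F)F)cc(C(F)(F)F)c1` gives 13 nM.

Of these two numbers compound 2 has the higher one, the weaker inhibitor, and the step of a 6.2-fold higher number from compound 1 to compound 2 (0.79 log units; beyond the scatter) lies beyond the scatter. Compound 3 `C[C@@H](O[C@H]1CN2C(=O)C=C(C3CCOCC3)CC2[C@@H]1c1ccc(F)cc1)c1cc(C(F)(F)F)cc(C(F)(F)F)c1` has not been measured; its change from compound 2 is oxan-4-yl in place of 4-hydroxycyclohex-1-en-1-yl on a double-bonded ring carbon. Going by the values given here, the single measured step concerns a different exchange on a double-bonded ring carbon, so it offers little guidance here. For compound 3 the expected step is a 1.2-fold higher number from compound 2 to compound 3 (0.06 log units; within the scatter), small and uncertain in direction. Compound 3 is therefore estimated at 15 nM, with a range from 4 nM to 50 nM.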

Compound 3, half-maximal inhibitory concentration: 3.2 nM
Compound 3: middle estimate off by 4.7-fold (0.67 log units), on the high side; measured number outside the range, below it.
By their numbers in this assay, from the lowest: compounds 1 and 3 (each within the scatter of the next); then compound 2.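

In this assay, oxan-4-yl in place of 4-hydroxycyclohex-1-en-1-yl gives a 4.1-fold lower number from compound 2 to compound 3 (0.61 log units; beyond the scatter), so this position can tell one non-aromatic ring from another. The step of a 1.5-fold higher number from compound 1 to compound 3 (0.18 log units; within the scatter) stays within the scatter, so a non-aromatic ring here can match the aromatic ring of compound 1. No measurement at hand explains these differences.

On these data alone, this exchange alters the hydroxy group, the double bond and the ring oxygen together, so their separate contributions stay open. As far as these compounds go, how a piperidin-4-yl amine or a carboxylic acid would fare at this position also remains unknown.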